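The source may hold more compounds than are shown below. What is called first, only, known or untested is meant among the compounds shown, and "the series" means these compounds.

Compound 1, `Cn1c(=O)c(S(=O)(=O)c2ccc(F)cc2[N+](=O)[O-])cc2cnc(Nc3ccc4[nH]ccc4c3)nc21`, is the most potent of the three compounds measured in a functional assay on DU-145 cells (Homo sapiens) for inhibition, read by trypan blue exclusion, with a stated time of 72 h; a lower number here means a stronger inhibitor, a higher number a weaker inhibitor: compound 1 gives 1500 nM. Compound 2, `Cn1c(=O)c(S(=O)(=O)c2ccc(F)cc2)cc2cnc(Nc3ccc4occc4c3)nc21`, gives 5000 nM in this assay, and compound 3, `Cn1c(=O)c(S(=O)(=O)c2ccc(Cl)cc2)cc2cnc(Nc3cnc4ccccc4c3)nc21`, gives 15000 nM; both gaps to compound 1 lie beyond the usual scatter. Among the measured compounds shown here, compounds 2 and 3 differ from compound 1 in more than one place, so no single step among the measured compounds isolates the group on the sulfonyl sulfur.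

Compound 4, `Cc1ccc(S(=O)(=O)c2cc3cnc(Nc4ccc5[nH]ccc5c4)nc3n(C)c2=O)cc1`, differs from compound 1 only there: 4-methylphenyl in place of 4-fluoro-2-nitrophenyl on a sulfonyl sulfur. Compound 2, which also carries a simpler substituted phenyl on the sulfonyl sulfur, gives 5000 nM, and compound 3, which likewise does, gives 15000 nM, so a move toward a higher number in this assay is expected for compound 4. The step is expected to be a 2.3-fold higher number from compound 1 to compound 4 (0.37 log units; beyond the scatter), of moderate size, beyond the scatter but not large. Compound 4 is therefore estimated at 3500 nM, within a range of 900 nM to 14000 nM.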

Compound 4, half-maximal inhibitory concentration: 750 nM
For compound 4 the middle estimate is 4.7-fold (0.67 log units) above the measured one; the whole stated range lies above it.
By their numbers in this assay, from the lowest: compounds 4 and 1 (each within the scatter of the next); then compound 2; then compound 3.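

On a sulfonyl sulfur, with the rest of compound 1 unchanged, 4-methylphenyl in place of 4-fluoro-2-nitrophenyl gives a 2.0-fold lower number from compound 1 to compound 4 (0.30 log units; within the scatter) in this assay. This first single-place comparison at the position does not separate the two groups, so in this pair the nitro and fluoro substituents are not required for inhibition at this level. No measurement shown here offers an explanation for this result.

Compound 2 and compound 3 differ from compound 1 and compound 4 in more than one place, so only these two groups on the sulfonyl sulfur can be compared directly. As far as these compounds go, it remains open whether a phenyl bearing a carboxylic acid or an aminomethyl group, or a butyl chain in place of the aromatic ring, would shift the number beyond the scatter.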